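The source may report more compounds than this note shows. Statements on the series, on what has been measured and on what is new or still open speak of the compounds shown alone.

Measured so far:
compound 1 `CCCCCCCCOC(=O)C(CCCCN1C(=O)CCC1=O)N1CCCCC1=O` — > 6250 nM
compound 2 `CCCCCCCCCCOC(=O)C(CCCCN1C(=O)CCC1=O)N1CCCCC1=O` — > 6250 nM

In an ADME assay on SK-N-MC cells (Homo sapiens) for antiproliferative activity, read by MTT assay, with a stated time of 72 h (a higher number here means a weaker inhibitor, a lower number a stronger inhibitor), compound 1 gives > 6250 nM, which is a limit of the assay and not a number. In this assay compound 2 gives > 6250 nM, likewise a limit. The step that the two limits leave unreadable from compound 1 to compound 2 is therefore unreadable in size; both values sit at the limit of > 6250 nM in this assay, at which 2 of the 2 values shown sit, and nothing beyond that is shown for the series.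

Compound 3 `CCCCCCCCCCCCOC(=O)C(CCCCN1C(=O)CCC1=O)N1CCCCC1=O` has not yet been measured in this assay. Going by the values given here, it differs from compound 1 by butyl in place of hydrogen on a saturated chain carbon, eight bonds along the chain from an oxygen next to a carbonyl group, the same change as the single measured step but carried two chain carbons further. That step, a step that the two limits leave unreadable from compound 1 to compound 2, gave no readable size, so no direction can be drawn from it, and both shown values are limits. Compound 3 is expected to sit at the limit as well, estimated at 12000 nM within a range from 5000 nM to 40000 nM. The expected step is a step that the limit leaves unreadable from compound 1 to compound 3.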

Compound 3, half-maximal inhibitory concentration: > 6250 nM
Compound 3: a limit, no number (the forecaster's own chance of this, stated with the estimate: 85%); the middle value is on the limit's open side.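

In this assay, going by these compounds alone, compound 3 gives > 6250 nM as a limit and not a number, so no step among compound 1, compound 2 and compound 3 can be read. The compounds shown leave open whether chain length changes the activity at all, since every value sits at one limit: the limit of > 6250 nM in this assay, at which 3 of the 3 values shown sit.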